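The source may report more compounds than this note shows. Statements on the series, on what has been measured and on what is new or still open speak of the compounds shown alone.

In a functional assay on A-431 cells (Homo sapiens) for inhibition, read by MTT assay, with a stated time of 72 h (on this read-out higher numbers stand for weaker inhibition and lower numbers for stronger inhibition), compound 1 `COc1ccc(-c2nnc(SCCCN3CCN(c4nc5ccccc5o4)CC3)o2)cc1` gives 52700 nM and compound 2 `Fc1ccc(-c2nnc(SCCCN3CCN(c4nc5ccccc5o4)CC3)o2)cc1` gives 136000 nM, the higher of these two numbers and so the weaker inhibition. Compound 3 `Brc1ccc(-c2nnc(SCCCN3CCN(c4nc5ccccc5o4)CC3)o2)cc1` differs from compound 2 at one spot: bromo in place of fluoro on an aromatic carbon, para to a large group. Going by the values given here, only one measured step bears on this, a 2.6-fold higher number from compound 1 to compound 2 (0.41 log units; beyond the scatter), which is modest and involves no bromo. A modest fall in the number is therefore expected, estimated as a 1.4-fold lower number from compound 2 to compound 3 (0.16 log units; within the scatter). For compound 3 the estimated value is 95000 nM, with an expected range from 40000 nM to 220000 nM.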

Compound 3, half-maximal inhibitory concentration: 57800 nM
Compound 3: the middle estimate sits 1.6-fold (0.22 log units) above what was measured, within the range that was stated.
By their numbers in this assay, from the lowest: compounds 1 and 3 (each within the scatter of the next); then compound 2.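

In this assay, exchanging the 4-fluorophenyl for the 4-bromophenyl gives a 2.4-fold lower number from compound 2 to compound 3 (0.37 log units; beyond the scatter), so the choice of halogen at this place, para to a large group, does change the number. Bromo and methoxy cannot be told apart here, with a 1.1-fold higher number from compound 1 to compound 3 (0.04 log units; within the scatter), which leaves fluoro as the one of these three groups that stands apart. No measurement shown explains why fluoro differs. As far as these compounds go, whether a chloro, a nitrile or an amine at this place would sit with fluoro or with bromo and methoxy stays open. So does whether the same exchange would have a similar effect on a different core.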